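Two Limits in Hand, a Third Compound Awaited

The source may hold more compounds than are shown below. What is called first, only, known or untested is meant among the compounds shown, and "the series" means these compounds.

Compound 1 `CCn1cc(C(=O)N2N=C(c3cc4ccccc4o3)CC2c2ccc(N(C)C)cc2)c(=O)c2ccc(C)nc21` gives in this assay a limit, > 206000 nM.
Compound 2 `CCn1cc(C(=O)N2N=C(c3cc4ccccc4o3)CC2c2ccccc2[N+](=O)[O-])c(=O)c2ccc(C)nc21` gives in this assay a limit, > 85400 nM.

Among the compounds with values here, in an ADME assay on Vero cells (Chlorocebus sabaeus) for cytotoxicity, read by MTT assay, with a stated time of 72 h (a higher number here means a weaker inhibitor, a lower number a stronger inhibitor), compound 2 stands only at a limit, and the one other value shown is likewise a limit. Within the data shown here, the single measured step, a step that the two limits leave unreadable from compound 1 to compound 2, cannot be sized because the limit of > 206000 nM in this assay, at which 1 of the 2 values shown sits, and the limit of > 85400 nM in this assay, at which 1 of the 2 values shown sits, are both limits rather than numbers.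

Compound 3 `CCn1cc(C(=O)N2N=C(c3cc4ccccc4o3)CC2c2ccc(OC)cc2)c(=O)c2ccc(C)nc21` differs from compound 2 by 4-methoxyphenyl in place of 2-nitrophenyl on a saturated ring carbon. Among the measured compounds shown here, the only step that bears on this change is the unreadable one from compound 1 to compound 2, so no direction for the new change can be read from it, and nothing beyond the scatter is expected in this assay.

Compound 3 is therefore expected to sit around 150000 nM, within 60000 nM to 400000 nM, most probably again as a limit. The expected step is a step that the limit leaves unreadable from compound 2 to compound 3.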

Compound 3, half-maximal inhibitory concentration: > 156000 nM
Compound 3 was reported as a limit; the forecaster's own chance of this, stated with the estimate: 75%; at least 1.0-fold (0.01 log units) between middle value and limit.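

In this assay, compound 3 gives only a limit, as do compound 1 and compound 2, so no step among these three compounds can be read. The compounds shown leave open how the groups on the saturated ring carbon rank in this assay, since none has a measured number.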